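This account rests on a few compounds, and the source may have more. Where it says the series, first, only, none or still open, it means among the compounds named here.

Measured compounds in an assay on membranes from HEK293 cells for displacement of a labelled ligand from adenosine receptor A2b (Homo sapiens), read by scintillation counting, with a stated time of 30 min, tested at 1 uM; a lower number here means less inhibition, a higher number more inhibition at the concentration tested (going by the name of the read-out):

- compound 1, `CC1=C(C(=O)NC(C)C)C(c2ccco2)NC(=O)N1`: 2%
- compound 2, `CCN(CC)C(=O)C1=C(C)NC(=O)NC1c1ccco1`: 31%
- compound 3, `CC1=C(C(=O)NC(C)C)C(c2ccoc2)NC(=O)N1`: 3%

Of the compounds shown here, three sharing one core have been measured in this assay. Compound 1 and compound 2 differ in one place, (diethylamino in place of isopropylamino on a carbonyl carbon), and that change produced a number 29 percentage points higher from compound 1 to compound 2 (beyond the scatter). Compound 1 and compound 3 are built from the same atoms joined differently, (furan-3-yl in place of furan-2-yl on a saturated ring carbon), and here the step was a number 1 percentage points higher from compound 1 to compound 3 (within the scatter), so compound 1 and compound 3 are not told apart by this assay. Compound 3 stands within the scatter of compound 1 and beyond it only from compound 2.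

Compound 4, `CCN(CC)C(=O)C1=C(C)NC(=O)NC1c1ccoc1`, has not been measured. It differs from compound 3 by diethylamino in place of isopropylamino on a carbonyl carbon. This is the same change that turns compound 1 into compound 2: the group that leaves, the group that enters and the place on the carbonyl carbon are described in the same words for both pairs. The two cores differ only as described for compound 1 and compound 3, a swap of furan-3-yl for furan-2-yl on the saturated ring carbon.

Among the compounds with values here, because a number 29 percentage points higher from compound 1 to compound 2 (beyond the scatter) was the one step beyond the scatter seen so far, and because the change from compound 3 to compound 4 is the same one, a step of similar size, a number 25 percentage points higher from compound 3 to compound 4 (beyond the scatter), is expected. That rests on a single earlier instance, so the spread is wide. Compound 4 is estimated at 28%, with a likely range from 12% to 45%.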

Compound 4, a percentage reported as inhibition, at one concentration (the size of the read-out at that concentration, not a potency): 12%
The estimate for compound 4 lay 16 percentage points above the measured number, and the stated range covers the measured number.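

On the core of compound 3, the change to diethylamino gave a number 9 percentage points higher from compound 3 to compound 4 (within the scatter), so in this assay the rise seen on the core of compound 1 did not carry over at its full size: the same change on two cores in this assay, a number 29 percentage points higher (beyond the scatter) from compound 1 to compound 2 and a number 9 percentage points higher (within the scatter) from compound 3 to compound 4, 20 percentage points apart, beyond the scatter of two such steps. Read the other way, the swap of furan-3-yl for furan-2-yl, which could not be told apart between the two isopropylamino compounds, gave a number 19 percentage points lower from compound 2 to compound 4 (beyond the scatter) between the two diethylamino compounds, so the two changes do not simply add up in these four compounds: the same change on two cores in this assay, a number 1 percentage points higher (within the scatter) from compound 1 to compound 3 and a number 19 percentage points lower (beyond the scatter) from compound 2 to compound 4, 20 percentage points apart, beyond the scatter of two such steps. Within the data shown here, this shows that the size of the step depends on the core within this small set, but it rests on only two pairs read at one concentration, and it shows neither why the cores differ nor how the change would behave on any further core.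

The compounds shown leave open whether a cyclic amine such as pyrrolidine or morpholine, or a longer chain such as dipropylamino, on the carbonyl carbon would depend on the furan in the same way. They also leave open how a thiophene or a phenyl on the saturated ring carbon would compare with either furan, and whether these differences would hold up as full potency values.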